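The source may hold more compounds than are shown below. What is called first, only, known or untested is meant among the compounds shown, and "the series" means these compounds.

Compound 1 `COc1cc2c(Oc3ccc(NC(=O)c4nn(-c5ccccc5)c(=O)cc4C)cc3F)ccnc2cc1OCCCN1CCCC1`: 120 nM
Compound 2 `COc1cc2c(Oc3ccc(NC(=O)c4nn(-c5ccccc5)c(=O)cc4C)cc3F)ccnc2cc1OCCCN1CCCCC1`: 160 nM

Measured in a functional assay on MKN-45 cells (Homo sapiens) for inhibition, read by MTT assay, with a stated time of 72 h (a higher number here means a weaker inhibitor, a lower number a stronger inhibitor), compound 1 and compound 2 stand close together, as the step of a 1.3-fold higher number from compound 1 to compound 2 (0.12 log units; within the scatter) shows; compound 2 is not set apart from compound 1 on these numbers. Compound 3 `COc1cc2c(Oc3ccc(NC(=O)c4nn(-c5ccccc5C(F)(F)F)c(=O)cc4C)cc3F)ccnc2cc1OCCCN1CCCCC1` differs from compound 2 by trifluoromethyl in place of hydrogen on an aromatic carbon. Within the data shown here, the only measured step changes the ring on the saturated chain and says nothing about a change on the phenyl ring, so no step in this assay can be read across. Among the measured compounds shown here, the estimate for compound 3 therefore rests on no measured precedent, and a 1.4-fold higher number from compound 2 to compound 3 (0.14 log units; within the scatter) is expected with a wide range. Compound 3 is expected to give 220 nM in this assay, between 60 nM and 800 nM.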

Compound 3, half-maximal inhibitory concentration: 90 nM
Compound 3: middle estimate off by 2.4-fold (0.39 log units), on the high side, within the range that was stated.
By their numbers in this assay, from the lowest: compounds 3, 1 and 2 (each within the scatter of the next).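

Among these compounds, compound 3 gives the first reading of a change on the phenyl ring, as the earlier compounds differed only in the ring on the saturated chain. In this assay, trifluoromethyl in place of hydrogen on this aromatic carbon, ortho to a large group, gives a 1.8-fold lower number from compound 2 to compound 3 (0.25 log units; within the scatter), so 2-(trifluoromethyl)phenyl is not set apart from phenyl on these numbers. Nothing measured here bears on a cause for this result.

The compounds shown leave open how a methoxy group, a nitrile or a single fluorine would read at this carbon. They also leave open whether trifluoromethyl on another carbon of the phenyl ring would give a similar number.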